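The compounds below may be only part of what the source reports. "The series", "measured", "known", "first", "only" and "open" are said of these compounds alone.

Compound 1 `Cc1ccc2oc(-c3ccc(NC(=O)CN4CCN(CCCN(C)C)CC4)c(C)c3)nc2c1` and compound 3 `Cc1cc(-c2nc3cc(F)ccc3o2)ccc1NC(=O)CN1CCN(CCCN(C)C)CC1` share one core and differ only in a fluoro in place of methyl on an aromatic carbon; in a functional assay on MCF7 cells (Homo sapiens) for cytotoxicity, read by MTT assay, with a stated time of 24 h (a higher number here means a weaker inhibitor, a lower number a stronger inhibitor), compound 1 gives 19800 nM and compound 3 gives 7770 nM, a step of a 2.5-fold lower number from compound 1 to compound 3 (0.41 log units; beyond the scatter). Compound 2 `Cc1cc(-c2nc3cc(Cl)ccc3o2)ccc1NC(=O)CCl` carries a chloroacetamide instead of the longer amide side chain. In this assay compound 2 gives only a limit, > 100000 nM. Compound 2 thus stands at the limit of > 100000 nM in this assay, at which 1 of the 3 values shown sits. Compound 4 `Cc1ccc2oc(-c3ccc(NC(=O)CCl)c(C)c3)nc2c1` differs from compound 2 by methyl in place of chloro on an aromatic carbon. Among the measured compounds shown here, the one measured step that bears on this, a 2.5-fold lower number from compound 1 to compound 3 (0.41 log units; beyond the scatter), ran the opposite way, halogen replacing methyl and lowering the number; here methyl replaces a halogen, so no lowering is expected. Compound 4 is therefore expected to give 150000 nM in this assay, between 60000 nM and 400000 nM, most likely again only a limit. This expectation amounts to a step that the limit leaves unreadable from compound 2 to compound 4.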

Compound 4, half-maximal inhibitory concentration: 96500 nM
Compound 4: the middle estimate sits 1.6-fold (0.19 log units) above what was measured; low and high end bracket the measured number.
By their numbers in this assay, from the lowest: compound 3; then compound 1; then compound 4. At a limit, above all of these: compound 2.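

With methyl in place of chloro on this aromatic carbon, this assay records an at least 1.0-fold lower number from compound 2 to compound 4 (0.01 log units; that floor lies within the scatter) and so shows no readable change at this position with the chloroacetamide side chain. Compound 2 gives > 100000 nM as a limit of the assay. Among the compounds shown here, compound 4 gives 96500 nM as a measured number, the first reading at this position with that side chain.

Going by these compounds, what chloro at this position gives with the longer amide side chain stays open, and so does the effect of a methoxy group or a nitrile there.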